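Swapping a Six-Membered Ring for a Five-Membered One

A few compounds are considered here, and "the series" means these few. Any claim that something is new, unique, unknown or untested is made for them only; others in the source may bear on it.

Measured so far:
Compound 1 `CN(c1ccc(Oc2ncnc3ccsc23)cc1)c1nccc(N2CCCC2)n1`: in a functional assay on A549 cells (Homo sapiens) for inhibition, read by MTT assay, with a stated time of 72 h, tested at 20 uM (a higher number here means more inhibition at the concentration tested (going by the name of the read-out), a lower number less inhibition), compound 1 gives 63.9%
Compound 2 `c1cc(N2CCCCC2)nc(Nc2ccc(Oc3ncnc4ccsc34)cc2)n1`: in this assay compound 2 gives 59.9%

Compound 2 holds the lower of the two numbers, yet its value sits within the scatter of compound 1, so the two are not separated by the measurement. Compound 3 `c1cc(N2CCCC2)nc(Nc2ccc(Oc3ncnc4ccsc34)cc2)n1` differs from compound 2 by one change: pyrrolidin-1-yl in place of piperidin-1-yl on an aromatic carbon. For the measured compounds named here, no measured pair shows this change on its own. In this assay the step is expected to be small, in no particular direction, staying within the scatter. Compound 3 is therefore estimated at 61%, between 45% and 76%, which means an expected step of a number 1.1 percentage points higher from compound 2 to compound 3 (within the scatter).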

Compound 3, a percentage reported as inhibition, at one concentration (the size of the read-out at that concentration, not a potency): 23.2%
Compound 3: the middle estimate sits 37.8 percentage points above what was measured; the measured number lies below the stated range.
By their numbers in this assay, from the lowest: compound 3; then compounds 2 and 1 (each within the scatter of the next).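

In this assay, this aromatic carbon proves sensitive to ring size: there is a number 36.7 percentage points lower from compound 2 to compound 3 (beyond the scatter) when pyrrolidin-1-yl replaces piperidin-1-yl, with hydrogen on the nitrogen on the aromatic ring. That nitrogen also matters, as there is a number 40.7 percentage points lower from compound 1 to compound 3 (beyond the scatter) when hydrogen replaces methyl, with pyrrolidin-1-yl kept in place. No measurement here bears on the reason for either drop.

The compounds shown leave open whether a morpholine ring or an open-chain dimethylamino group on this carbon would keep the higher level of inhibition. They also leave open how an ethyl group on that nitrogen would compare.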